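Urea aryl swap on a benzylpiperazine-bearing core

This account rests on a few compounds, and the source may have more. Where it says the series, first, only, none or still open, it means among the compounds named here.

Compound 1 `Cc1cc(Cl)ccc1NC(=O)Nc1nc(Sc2c[nH]c3ccccc23)cc(N2CCN(Cc3ccccc3)CC2)n1` is the starting point of this step. In a functional assay on A549 cells (Homo sapiens) for inhibition, with a stated time of 72 h (on this read-out higher numbers stand for weaker inhibition and lower numbers for stronger inhibition), compound 1 returns only a limit, > 50000 nM, so no number stands for it; it sits at the limit of > 50000 nM in this assay, at which 1 of the 3 values shown sits, and nothing more can be read off for it from this read-out. Two further compounds on the same shared core carry other substituents at both variable positions: compound 2 `O=C(Nc1ccc(Cl)cc1)Nc1nc(Sc2c[nH]c3ccccc23)cc(N2CCCC2)n1` gives 6410 nM in this assay, and compound 3 `Cc1cc(Cl)ccc1NC(=O)Nc1nc(NC2CC2)cc(Sc2c[nH]c3ccccc23)n1` gives 31500 nM. Neither differs from compound 1 in a single place, so their values are shown side by side only, without a step.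

Compound 4 `COc1ccc(NC(=O)Nc2nc(Sc3c[nH]c4ccccc34)cc(N3CCN(Cc4ccccc4)CC3)n2)cc1` is the next compound to be measured. It differs from compound 1 in one place: 4-methoxyphenyl in place of 4-chloro-2-methylphenyl on an amide-type nitrogen whose other neighbour is a carbonyl carbon. Within the data shown here, no measured step from compound 1 to anything is available, and compound 1 itself is only a limit, so the size of the change cannot be anchored; the expected step from compound 1 to compound 4 is an at least 1.2-fold lower number from compound 1 to compound 4 (0.09 log units; that floor lies within the scatter), with no reliable direction. Compound 4 is expected to give about 40000 nM in this assay, estimated between 8000 nM and 120000 nM, and it may again return only a limit.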

Compound 4, half-maximal inhibitory concentration: 42300 nM
Compound 4: middle estimate off by 1.1-fold (0.02 log units), on the low side; the measured number falls inside the stated range.
By their numbers in this assay, from the lowest: compound 2; then compounds 3 and 4 (each within the scatter of the next). At a limit, above all of these: compound 1.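

With 4-methoxyphenyl on the amide-type nitrogen, compound 4 gives a measurable value in this assay, 42300 nM, on the same benzylpiperazine-bearing core. Compound 1 returns only a limit, > 50000 nM. The swap can therefore be read only as an at least 1.1-fold lower number from compound 1 to compound 4 (0.07 log units; that floor lies within the scatter), which establishes neither the size of the change nor a real gain at this position: the limit of > 50000 nM in this assay, at which 1 of the 4 values shown sits.

As far as these compounds go, whether a urea aryl carrying an amine or a carboxylic acid, or a pyridyl ring in place of the phenyl, would shift the value on this core remains open. Compounds 2 and 3 differ from compound 1 at both variable positions, so the contribution of the benzylpiperazine cannot be separated from that of the urea aryl.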